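The source may report more compounds than this note shows. Statements on the series, on what has been measured and on what is new or still open speak of the compounds shown alone.

In a functional assay (Homo sapiens) for inhibition (a lower number here means a stronger inhibitor, a higher number a weaker inhibitor), compound 1 (`CSc1ccc(CSc2nc(-c3ccc(F)cc3)c(-c3ccncc3)[nH]2)cc1`) gives 670 nM, and compound 2 (`C[S+]([O-])c1cc(CSc2nc(-c3ccc(F)cc3)c(-c3ccncc3)[nH]2)ccc1O`) gives 2300 nM. Compound 2 therefore has the higher of the two numbers and is the weaker inhibitor of this pair. Compound 3 (`C[S+]([O-])c1ccc(O)c(CSc2nc(-c3ccc(F)cc3)c(-c3ccncc3)[nH]2)c1`) has not yet been measured. It contains the same atoms as compound 2, joined differently: a group of 10 heavy atoms (7 carbon, 2 oxygen, 1 sulfur; one six-membered aromatic ring of carbon only) in place of a group of 10 heavy atoms (7 carbon, 2 oxygen, 1 sulfur; one six-membered aromatic ring of carbon only), on a saturated chain carbon bound to a sulfur. Among the compounds with values here, only one measured step bears on this change: a 3.4-fold higher number from compound 1 to compound 2 (0.54 log units; beyond the scatter). That step is modest, but it involves a change in group size, whereas compound 2 and compound 3 have groups of equal size. Within the data shown here, no measured pair shows what rearranging the same atoms does, so no direction can be favoured. The expected result is a 1.2-fold lower number from compound 2 to compound 3 (0.06 log units; within the scatter), although a modest shift either way would not be surprising. For compound 3, the estimated value is 2000 nM, with an expected range of 650 nM to 6500 nM.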

Compound 3, half-maximal inhibitory concentration: 1000 nM
Beside the measured number, compound 3's estimate is 2.0-fold (0.30 log units) above it, and the stated range covers the measured number.
By their numbers in this assay, from the lowest: compounds 1 and 3 (each within the scatter of the next); then compound 2.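

In this assay, within the data shown here, the earlier compounds showed only that a larger group on the saturated chain carbon bound to a sulfur could give a weaker inhibitor, and they said nothing about how the atoms of that group are arranged. Joining the same atoms differently gives a 2.3-fold lower number from compound 2 to compound 3 (0.36 log units; beyond the scatter) and so shows that the arrangement matters at this position, even though the group's size and atom counts stay the same. With a 1.5-fold higher number from compound 1 to compound 3 (0.17 log units; within the scatter) the larger group of compound 3 cannot be told apart from the smaller group of compound 1, so greater size alone does not bring a loss in this assay.

Going by these compounds, whether an amine or a carboxylic acid at this position would give a stronger or weaker inhibitor remains open. Nothing available here explains why the two arrangements differ.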